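A few compounds are considered here, and "the series" means these few. Any claim that something is new, unique, unknown or untested is made for them only; others in the source may bear on it.

Measured in an ADME assay on microsomes from liver (Homo sapiens) for pharmacokinetics; on this read-out lower numbers stand for slow clearance and higher numbers for fast clearance:

Compound 1 `Cc1c(Nc2nc(N)c3c(C#N)c(N4CCC[C@H]4C)n(C)c3n2)cnn1CC1(O)COC1`: 35 mL/min/kg
Compound 2 `Cc1nn(CC(C)(C)O)cc1Nc1nc(N)c2c(C#N)c(N3CCC[C@H]3C)n(C)c2n1`: 50 mL/min/kg

Compound 1 sits within the scatter of compound 2, so these two numbers set no order between them. Both lie in one narrow band, and that band is the only reference available. Compound 3 `Cc1c(Nc2nc(N)c3c(C#N)c(N4CCC[C@H]4C)n(C)c3n2)cnn1[C@@H]1CCOC1` is the next to be read, and it departs from compound 1 as follows: oxolan-3-yl in place of (3-hydroxyoxetan-3-yl)methyl on an aromatic nitrogen. In words, oxolan-3-yl stands in place of (3-hydroxyoxetan-3-yl)methyl on an aromatic nitrogen. Going by the values given here, no measured pair isolates a change at this place, so the data give neither a size nor a direction for it. No step beyond the scatter is therefore expected in this assay, and the reference remains compound 1 at 35 mL/min/kg. The expected step is a 1.1-fold higher number from compound 1 to compound 3 (0.06 log units; within the scatter). For compound 3 the estimated value is 40 mL/min/kg, with an expected range of 20 mL/min/kg to 80 mL/min/kg.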

Compound 3, clearance: 28.3 mL/min/kg
Compound 3: middle estimate off by 1.4-fold (0.15 log units), on the high side; the measured number falls inside the stated range.
By their numbers in this assay, from the lowest: compounds 3, 1 and 2 (each within the scatter of the next).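

Going by these compounds alone, the only pair that isolates this place in this assay gives a 1.2-fold lower number from compound 1 to compound 3 (0.09 log units; within the scatter) for oxolan-3-yl in place of (3-hydroxyoxetan-3-yl)methyl on the aromatic nitrogen. The leaving group carries a hydrogen-bond donor and the entering group none, and a four-membered ring gives way to a five-membered ring with a defined stereocentre, yet the clearance numbers of this pair stay within the scatter. Nothing available accounts for this result.

Going by these compounds, whether a chain ending in an amine or a carboxylic acid on this aromatic nitrogen would move the number beyond the scatter remains open. On these data alone, the opposite configuration of the oxolan-3-yl group is also open, so the defined stereocentre has no reading of its own.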